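The source may report more compounds than this note shows. Statements on the series, on what has been measured and on what is new or still open speak of the compounds shown alone.

Of the compounds shown here, three sharing one core have been measured in a physicochemical assay, with a stated time of 30 min; on this read-out higher numbers stand for weaker inhibition and lower numbers for stronger inhibition. Compound 1 `CCc1ccc(NC(=O)C2Cc3cc(OC)c(OC)cc3C2=O)cc1` gives 76.2 ug/mL, compound 2 `CCOc1ccc(NC(=O)C2Cc3cc(OC)c(OC)cc3C2=O)cc1` gives 48.2 ug/mL, and compound 3 `COc1cc2c(cc1OC)C(=O)C(C(=O)Nc1ccc(F)cc1)C2` gives 55 ug/mL. The step of a 1.4-fold lower number from compound 1 to compound 3 (0.14 log units; within the scatter) and the step of a 1.1-fold higher number from compound 2 to compound 3 (0.06 log units; within the scatter) both stay within the scatter, so compound 3 sits in the same band as the other two. Compound 4 `CCc1cccc(NC(=O)C2Cc3cc(OC)c(OC)cc3C2=O)c1` differs from compound 3 in one place: 3-ethylphenyl in place of 4-fluorophenyl on an amide-type nitrogen. Every measured step also exchanges one group on an aromatic carbon, and a 1.6-fold lower number from compound 1 to compound 2 (0.20 log units; within the scatter) stayed within the scatter as well, so no step beyond the scatter is expected here. The expected step is a 1.1-fold higher number from compound 3 to compound 4 (0.04 log units; within the scatter). Compound 4 is therefore estimated at 60 ug/mL, with a range from 30 ug/mL to 120 ug/mL in this assay.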

Compound 4, half-maximal inhibitory concentration: 64.1 ug/mL
Estimate against measurement, compound 4: 1.1-fold (0.03 log units) below, and the stated range covers the measured number.
By their numbers in this assay, from the lowest: compounds 2, 3, 4 and 1 (each within the scatter of the next).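

Exchanging the entire substituted phenyl group on the amide-type nitrogen, rather than only a group on its ring, still stays within the scatter: 3-ethylphenyl in place of 4-fluorophenyl gives a 1.2-fold higher number from compound 3 to compound 4 (0.07 log units; within the scatter). The same holds when the two ethylphenyl groups are compared directly, with a 1.2-fold lower number from compound 1 to compound 4 (0.08 log units; within the scatter), so in this assay these compounds do not separate by where the ethyl group sits. Nothing available bears on why these numbers stay so close. From the compounds shown here alone, whether an amine or a carboxylic acid on this phenyl ring would give a step beyond the scatter remains open. So does the effect of a longer chain in place of ethyl.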